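Swapping the Nitropyrazole Amide for a Trimethylpyrrole

The compounds below may be only part of what the source reports. "The series", "measured", "known", "first", "only" and "open" are said of these compounds alone.

Compound 1 `Cn1ncc([N+](=O)[O-])c1C(=O)Nc1ccc2nc(NC(=O)C3CCCCC3)sc2c1` is one of three amides that share a common core and have been measured for cytotoxicity in a functional assay on WI-38 VA13 cells (Homo sapiens) for cytotoxicity; on this read-out higher numbers stand for an effect only at larger amounts of compound and lower numbers for an effect already at smaller amounts; in it compound 1 gives 0.026 ug/mL, the lowest number of the three. Compound 2 `N#Cc1cccc(C(=O)Nc2ccc3nc(NC(=O)C4CCCCC4)sc3c2)c1` gives 0.52 ug/mL in this assay, and compound 3 `Cc1ccc(C(=O)Nc2ccc3nc(NC(=O)C4CCCCC4)sc3c2)cc1` gives 5.1 ug/mL. The steps away from compound 1 both run upward: a 20-fold higher number from compound 1 to compound 2 (1.30 log units; beyond the scatter) and a 200-fold higher number from compound 1 to compound 3 (2.29 log units; beyond the scatter). Between the two phenyl amides there is a further rise, a 9.8-fold higher number from compound 2 to compound 3 (0.99 log units; beyond the scatter).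

Compound 4 `Cc1cc(C(=O)Nc2ccc3nc(NC(=O)C4CCCCC4)sc3c2)c(C)n1C` has not yet been measured in this assay. It differs from compound 1 in one place: 1,2,5-trimethyl-1H-pyrrol-3-yl in place of 1-methyl-4-nitro-1H-pyrazol-5-yl on a carbonyl carbon. Both measured steps that start from compound 1 replace the 1-methyl-4-nitro-1H-pyrazol-5-yl group with another aromatic ring on the carbonyl carbon, and each raised the number by a large amount, so the expectation for compound 4 rests on the steps of a 20-fold higher number from compound 1 to compound 2 (1.30 log units; beyond the scatter) and a 200-fold higher number from compound 1 to compound 3 (2.29 log units; beyond the scatter). The 1,2,5-trimethyl-1H-pyrrol-3-yl ring carries no nitro group, and a large upward step is therefore expected in this assay. Compound 4 is expected to give 3 ug/mL, within a range from 0.4 ug/mL to 20 ug/mL, which amounts to an expected step of a 120-fold higher number from compound 1 to compound 4 (2.06 log units; beyond the scatter).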

Compound 4, half-maximal effective concentration: > 6.2 ug/mL
Compound 4: no number, only a limit (the forecaster's own chance of this, stated with the estimate: 10%); middle value at least 2.0-fold (0.31 log units) away from the limit.
By their numbers in this assay, from the lowest: compound 1; then compound 2; then compound 3. At a limit, above all of these: compound 4.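

The reading for compound 4 in this assay is a limit and not a number: the limit of > 6.2 ug/mL in this assay, at which 1 of the 4 values shown sits.

Compound 4 keeps a five-membered aromatic ring on the carbonyl carbon, yet the step is still large, an at least 230-fold higher number from compound 1 to compound 4 (2.37 log units; beyond the scatter), so a ring of that size does not by itself keep the low number of compound 1, something the two phenyl amides could not show. The step of an at least 11-fold higher number from compound 2 to compound 4 (1.07 log units; beyond the scatter) is also beyond the scatter, and among the four compounds the low number stays with the 1-methyl-4-nitro-1H-pyrazol-5-yl group alone. The remaining step, an at least 1.2-fold higher number from compound 3 to compound 4 (0.08 log units; that floor lies within the scatter), has a floor within the scatter, so that pair cannot be put in order.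

The compounds shown do not separate the nitro group from the pyrazole ring that carries it, so a 1-methyl-1H-pyrazol-5-yl group without the nitro, or a nitrophenyl group, could tell which of the two goes with the low number. Going by these compounds, how an amine in the place of the nitro group would stand also remains open.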